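Chalcone series: thiophen-2-yl in place of the aminophenyl

A few compounds are considered here, and "the series" means these few. Any claim that something is new, unique, unknown or untested is made for them only; others in the source may bear on it.

Measured so far in a functional assay on SW-620 cells (Homo sapiens) for antiproliferative activity, read by MTT assay, with a stated time of 24 h; a lower number here means a stronger inhibitor, a higher number a weaker inhibitor:
compound 1 `COc1ccc(C(=O)/C=C/c2ccc(N(C)C)cc2)c2c1C=CC(C)(C)O2` gives 570 nM.
compound 2 `COc1ccc(C(=O)/C=C/c2ccc(-c3ccccc3)cc2)c2c1C=CC(C)(C)O2` gives only a limit of the assay, > 10000 nM.
compound 3 `COc1ccc(C(=O)/C=C/c2ccc(N3CCCC3)cc2)c2c1C=CC(C)(C)O2` gives 7150 nM.

Compound 1 stands lowest of the two numbers, with compound 3 the nearest. The value of compound 2 is a limit (the limit of > 10000 nM in this assay, at which 1 of the 3 values shown sits). Both changes made at the dimethylamino of compound 1 were large: an at least 17-fold higher number from compound 1 to compound 2 (1.24 log units; beyond the scatter); a 13-fold higher number from compound 1 to compound 3 (1.10 log units; beyond the scatter). Between the other two the step is an at least 1.3-fold lower number from compound 2 to compound 3 (0.14 log units; that floor lies within the scatter).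

Compound 4 `COc1ccc(C(=O)/C=C/c2cccs2)c2c1C=CC(C)(C)O2` differs from compound 1 in the group on the chain: thiophen-2-yl in place of 4-(dimethylamino)phenyl on a double-bonded chain carbon bound to a double-bonded chain carbon. The dimethylamino of compound 1 leaves with its ring. The two measured steps that alter that dimethylamino both bear on this change, and both were large rises in the number, so a rise of similar size is expected for compound 4 in this assay, with a real chance that only a limit is reported. The estimate for compound 4 is 7000 nM, in the range 2000 nM to 20000 nM, which means an expected step of a 12-fold higher number from compound 1 to compound 4 (1.09 log units; beyond the scatter).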

Compound 4, half-maximal inhibitory concentration: > 10000 nM
Compound 4: no number, only a limit; the forecaster's own chance of this, stated with the estimate: 40%; at least 1.4-fold (0.15 log units) between middle value and limit.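

In this assay the whole 4-(dimethylamino)phenyl gives way to thiophen-2-yl (an at least 17-fold higher number from compound 1 to compound 4 (1.24 log units; beyond the scatter)), so the large rise seen with changes to the dimethylamino alone also appears when the ring leaves with it. Compound 4 gives only a limit, the same one as compound 2, and the two cannot be ordered: the limit of > 10000 nM in this assay, at which 2 of the 4 values shown sit. All three changes shown at this group give large rises, and compound 1 (570 nM) keeps the lowest number.

Because the dimethylamino and its ring leave together in compound 4, this step cannot show which of the two matters more. As far as these compounds go, whether a dimethylamino carried on the thiophen-2-yl, or a diethylamino or a plain amino group on the phenyl ring, would hold the number of compound 1 remains open.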